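Methyl on the benzyl group: compound 3 to compound 4

The source may report more compounds than this note shows. Statements on the series, on what has been measured and on what is new or still open speak of the compounds shown alone.

Of the compounds shown here, three have been measured in an ADME assay on J774.1 cells (Mus musculus) for cytotoxicity, with a stated time of 48 h; on this read-out lower numbers stand for an effect already at smaller amounts and higher numbers for an effect only at larger amounts of compound. Compound 1 `COC(=O)C1C(=O)C(C(=O)OC)[C@H](c2ccccn2)N(CCCCCCCC(=O)O)[C@@H]1c1ccccn1` gives 33.8 uM in this assay. Compound 2 `COC(=O)C1C(=O)C(C(=O)OC)[C@H](c2cccc([N+](=O)[O-])c2)N(Cc2ccc(OC)cc2)[C@@H]1c1cccc([N+](=O)[O-])c1` reaches only the limit of > 100 uM, so no number is known for it. Compound 3 `COC(=O)C1C(=O)C(C(=O)OC)[C@H](c2cccc([N+](=O)[O-])c2)N(Cc2ccccc2)[C@@H]1c1cccc([N+](=O)[O-])c1` likewise stops at the limit of > 100 uM in this assay. Among the measured compounds shown here, the single measured step that changes one place is a step that the two limits leave unreadable from compound 2 to compound 3; both of its ends rest at the limit of > 100 uM in this assay, at which 2 of the 3 values shown sit, so it gives no readable size, and it cannot be told how far compound 2 and compound 3 lie from compound 1.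

Compound 4 `COC(=O)C1C(=O)C(C(=O)OC)[C@H](c2cccc([N+](=O)[O-])c2)N(Cc2ccc(C)cc2)[C@@H]1c1cccc([N+](=O)[O-])c1` differs from compound 3 by methyl in place of hydrogen on an aromatic carbon. For the measured compounds named here, no measured step bears directly on this change, and the step from compound 2 to compound 3, the nearest comparison, has no readable size. Compound 4 is therefore expected to remain at the same limit in this assay, with an expected step that the limit leaves unreadable from compound 3 to compound 4. For compound 4 the estimate is 150 uM, in an expected range of 60 uM to 400 uM, most likely reported again only as a limit.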

Compound 4, concentration for half-maximal effect: 49.8 uM
Beside the measured number, compound 4's estimate is 3.0-fold (0.48 log units) above it; measured number outside the range, below it.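

In this assay the benzyl group proves sensitive to a small change at the place para to a large group: going from benzyl to 4-methylbenzyl, methyl in place of hydrogen gives an at least 2.0-fold lower number from compound 3 to compound 4 (0.30 log units; that floor lies within the scatter). Methyl in place of methoxy at this same place gives an at least 2.0-fold lower number from compound 2 to compound 4 (0.30 log units; that floor lies within the scatter), so these two groups do not behave alike here. The true size of both steps remains unknown because only a floor can be read from a limit: the limit of > 100 uM in this assay, at which 2 of the 4 values shown sit.

On these data alone, whether this shift belongs to methyl alone or also appears with ethyl, chloro or an amine at this place remains open. Also open, as far as these compounds go, is how a carboxylic acid or a longer chain on the benzyl ring would read in this assay.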